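The source may report more compounds than this note shows. Statements on the series, on what has been measured and on what is new or still open speak of the compounds shown alone.

Measured so far:
compound 1, `Cc1cc(=O)n(-c2ccccc2Cl)nc1C(=O)Nc1ccc(Oc2ncnc3c2ccn3C)cc1`: 4130 nM
compound 2, `Cc1cc(=O)n(-c2cccc(F)c2)nc1C(=O)Nc1ccc(Oc2ncnc3c2ccn3C)c(F)c1`: > 60000 nM

In a functional assay on MCF7 cells (Homo sapiens) for cytotoxicity, read by MTT assay, with a stated time of 72 h (on this read-out lower numbers stand for stronger inhibition and higher numbers for weaker inhibition), compound 1 gives 4130 nM. For compound 2 this assay reports only a limit, > 60000 nM, so compound 2 stands at the edge of what the assay can resolve, and the limit of > 60000 nM in this assay, at which 1 of the 2 values shown sits, records that one of the two values sits there. Compound 3 is `Cc1cc(=O)n(-c2ccccc2Cl)nc1C(=O)Nc1ccc(Oc2ncnc3c2ccn3C)c(F)c1`, not yet measured in this assay. It differs from compound 2 by 2-chlorophenyl in place of 3-fluorophenyl on an aromatic nitrogen. Among the compounds with values here, no measured pair shows this step on its own. Compound 1 carries the same 2-chlorophenyl as compound 3, and in this assay compound 1 gives a number rather than a limit, 4130 nM, so the step is expected to move toward stronger inhibition, beyond the scatter, by an at least 6.0-fold lower number from compound 2 to compound 3 (0.77 log units; beyond the scatter) in this assay. Compound 3 is accordingly expected to give 10000 nM in this assay, with a range from 3500 nM to 40000 nM.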

Compound 3, half-maximal inhibitory concentration: > 60000 nM
Compound 3 gave a limit, no number; the forecaster's own chance of this, stated with the estimate: 25%; middle value at least 6.0-fold (0.77 log units) from the limit.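

Within the data shown here, with the 2-chlorophenyl held constant, fluoro in place of hydrogen on an aromatic carbon gives the only readable step in this assay, an at least 14-fold higher number from compound 1 to compound 3 (1.16 log units; beyond the scatter), a step that rests on a limit for compound 3. The 2-chlorophenyl that accompanies a number in compound 1 thus does not give a number in compound 3, where that fluoro is the one difference. The step between 3-fluorophenyl and 2-chlorophenyl cannot be read, as compound 2 and compound 3 both stand at a limit: the limit of > 60000 nM in this assay, at which 2 of the 3 values shown sit.

From the compounds shown here alone, it remains open whether the 3-fluorophenyl gives a number when the fluoro on the aromatic carbon is replaced by hydrogen. Going by these compounds, it is also open whether a methoxy group or a chlorine at that carbon would give a number in this assay.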